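Working notes: from compound 2 to compound 3

A few compounds are considered here, and "the series" means these few. Any claim that something is new, unique, unknown or untested is made for them only; others in the source may bear on it.

Values in a functional assay on A549 cells (Homo sapiens) for inhibition, read by MTT assay, with a stated time of 48 h; a higher number here means a weaker inhibitor, a lower number a stronger inhibitor:
- compound 1 `COc1ccc(N(C)c2nc(C)nc3ccccc23)cc1C(=O)OCC[Se]C#N`: 353 nM
- compound 2 `COc1ccc(N(C)c2nc(C)nc3ccccc23)cc1C(=O)NCC[Se]C#N`: 187 nM

Among the compounds with values here, only one step has been measured: a 1.9-fold lower number from compound 1 to compound 2 (0.28 log units; within the scatter). Compound 2 therefore has no separate standing, as its value and that of compound 1 lie within the scatter of each other.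

The next case is compound 3 `COc1ccc(N(C)c2nc(C)nc3ccccc23)cc1C(=O)OCCCCCC[Se]C#N`. The change is a group of 10 heavy atoms (7 carbon, 1 nitrogen, 1 oxygen, 1 selenium; no ring) in place of a group of 6 heavy atoms (3 carbon, 2 nitrogen, 1 selenium; no ring), on a carbonyl carbon, on a carbonyl carbon whose other neighbours are: aromatic carbon. The measured step covers only the exchange between the ester and amide links, and it stayed within the scatter. Within the data shown here, no measured compound varies the chain length, so that part of the change is untested and the range must stay wide. In this assay, only a small rise is expected, with no clear step beyond the scatter. The expected change is a 1.5-fold higher number from compound 2 to compound 3 (0.18 log units; within the scatter). Compound 3 is estimated at 280 nM, with an expected range of 90 nM to 850 nM.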

Compound 3, half-maximal inhibitory concentration: 488 nM
Compound 3: middle estimate off by 1.7-fold (0.24 log units), on the low side; the range from low to high includes it.
By their numbers in this assay, from the lowest: compounds 2, 1 and 3 (each within the scatter of the next, the first and the last beyond it).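

In this assay, the longer chain on the ester link gives a 1.4-fold higher number from compound 1 to compound 3 (0.14 log units; within the scatter), so at this position lengthening the chain has no effect that can be told from the scatter. Within the data shown here, the first step beyond the scatter is a 2.6-fold higher number from compound 2 to compound 3 (0.42 log units; beyond the scatter), but it is modest and changes the link and the chain together, and neither change taken alone has produced a step beyond the scatter. Nothing available bears on the reason for this step.

Still open, on these data alone, is how an amide link carrying the longer chain of compound 3 would read, which would separate the contributions of link and chain. Also open, as far as these compounds go, are chains of intermediate length, a still longer chain, and a sulfur atom in place of the selenium.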